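The compounds below may be only part of what the source reports. "The series", "measured", "known", "first", "only" and "open" are said of these compounds alone.

Working notes on the nitro-containing series at an assay on 1321N1 cells for antagonist activity at P2Y purinoceptor 6 (Mus musculus), read by FLIPR and calcium flux; a lower number here means a stronger inhibitor, a higher number a weaker inhibitor.

Two compounds have numbers. Compound 1 `O=[N+]([O-])C1=Cc2cccc(Cl)c2OC1C(F)(F)F` gives 15200 nM in this assay. Compound 2 `CC[Si](C#Cc1ccc2c(c1)C=C([N+](=O)[O-])C(C(F)(F)F)O2)(CC)CC` gives 4940 nM in this assay. On these two numbers compound 1 stands with the highest, so it is the weaker inhibitor of the pair, and the gap to compound 2 lies beyond the usual scatter.

Compound 3 `O=[N+]([O-])C1=Cc2ccccc2OC1C(F)(F)F` has not been measured in this assay. It differs from compound 1 in one place: hydrogen in place of chloro on an aromatic carbon. For the measured compounds named here, no step between measured compounds isolates this change, so there is no direct reading of its size. Going by the values given here, the only measured neighbour, compound 2, carries a different substituent in a different place, and its value cannot be used to set the step.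

On that basis the step from compound 1 to compound 3 is expected to be small and uncertain in direction, most likely a modest move toward a higher number, a 1.4-fold higher number from compound 1 to compound 3 (0.16 log units; within the scatter). Compound 3 is therefore estimated at 22000 nM, with a range from 7000 nM to 70000 nM, the estimate leaning on the value of compound 1 at 15200 nM.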

Compound 3, half-maximal inhibitory concentration: 185000 nM
Compound 3: the middle estimate sits 8.4-fold (0.92 log units) below what was measured, and the stated range ends below it.
By their numbers in this assay, from the lowest: compound 2; then compound 1; then compound 3.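

Replacing chloro with hydrogen on this aromatic carbon, ortho to a fused ring and meta to a fused ring, gives a 12-fold higher number from compound 1 to compound 3 (1.09 log units; beyond the scatter) in this assay, so the substituent at this place has a large bearing on the number. The earlier compounds shown here could not show this, as no pair among them isolated a single change; compound 3 now gives the series a hydrogen reference against which a group at this carbon can be read. No measurement at hand explains why the step is so large.

The compounds shown leave open whether this step is particular to chloro or would be matched by another group at the same carbon, such as fluoro, bromo, methyl or methoxy. It also remains open whether a step of this size would recur on a core carrying the triethylsilyl ethynyl group of compound 2, as the pairs shown do not test chloro and hydrogen in that setting.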